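Sulfur enters a ring where the numbers stop at limits

The source may hold more compounds than are shown below. What is called first, only, known or untested is meant among the compounds shown, and "the series" means these compounds.

In a functional assay on MDA-MB-231 cells (Homo sapiens) for antiproliferative activity, read by MTT assay, with a stated time of 72 h (a lower number here means a stronger inhibitor, a higher number a weaker inhibitor), compound 1 (`CC(C)(C)C#Cc1cc(-c2ccc(/C=C/C(=O)O)cc2Cl)ccc1O`) gives > 10000 nM, which is a limit. Compound 2 (`Cc1cccc(C)c1-c1cc(-c2ccc(/C=C/C(=O)O)cc2Cl)ccc1O`) gives > 10000 nM, also a limit. Compound 3 (`CC1(c2cc(-c3ccc(/C=C/C(=O)O)cc3Cl)ccc2O)CCCCC1`) gives > 5000 nM, likewise a limit, so no number places it.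

Compound 4 (`CC1(c2cc(-c3ccc(/C=C/C(=O)O)cc3Cl)ccc2O)SCCCS1`) differs from compound 3 at one place, on an aromatic carbon ortho to a hydroxy group: a group of 7 heavy atoms (5 carbon, 2 sulfur; one six-membered non-aromatic ring with 2 hetero atoms) in place of a group of 7 heavy atoms (7 carbon; one six-membered non-aromatic ring of carbon only), on an aromatic carbon.

The nearest measured changes fall at that same place: a step that the two limits leave unreadable from compound 1 to compound 3, and a step that the two limits leave unreadable from compound 2 to compound 3. The series sits at the limit of > 10000 nM in this assay, at which 2 of the 3 values shown sit, and at the limit of > 5000 nM in this assay, at which 1 of the 3 values shown sits. None of these compounds shows the effect of putting sulfur into the ring.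

Compound 3 stands at > 5000 nM, and with only that limit to start from, no step beyond the scatter is expected in this assay. The expected step is a step that the limit leaves unreadable from compound 3 to compound 4, with no direction favoured. For compound 4 the estimate is 8000 nM, expected to fall between 3000 nM and 20000 nM, and another limit is the likeliest report.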

Compound 4, half-maximal inhibitory concentration: > 20000 nM
Compound 4: a limit, no number (the forecaster's own chance of this, stated with the estimate: 75%); at least 2.5-fold (0.39 log units) between middle value and limit.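

Compound 4 gives > 20000 nM as a limit and not a number. Its steps from compound 1, compound 2 and compound 3 therefore cannot be read. The compounds shown leave open whether putting sulfur into the ring changes activity in this assay at all.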